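Swapping the aromatic substituent in a chromene thioamide series

The source may report more compounds than this note shows. Statements on the series, on what has been measured and on what is new or still open speak of the compounds shown alone.

Of the compounds shown here, three sharing one core have been tested in a functional assay (aorta) with Rattus norvegicus as the target; a lower number here means that less compound is needed, a higher number that more compound is needed for the effect. Compound 1 `C/N=C(/S)C1=CC(C)(C)Oc2ccc(C#N)cc21` carries a cyano group on the aromatic ring and gives 21.4 nM. Compound 2 `C/N=C(/S)C1=CC(C)(C)Oc2ccc(C(F)(F)C(F)(F)F)cc21` carries a 1,1,2,2,2-pentafluoroethyl group in that place and gives 11.8 nM. Compound 3 `C/N=C(/S)C1=CC(C)(C)Oc2ccc(Br)cc21` carries a bromo group there and gives 15.1 nM. The number for compound 1 is the largest of the three, yet the steps of a 1.8-fold lower number from compound 1 to compound 2 (0.26 log units; within the scatter) and a 1.4-fold lower number from compound 1 to compound 3 (0.15 log units; within the scatter) both stay within the scatter, and so does the step of a 1.3-fold higher number from compound 2 to compound 3 (0.11 log units; within the scatter), so on these numbers the three compounds cannot be told apart.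

Compound 4 `CCc1ccc2c(c1)C(/C(S)=N\C)=CC(C)(C)O2` has not yet been measured. It differs from compound 1 in one place: ethyl in place of cyano on an aromatic carbon. For the measured compounds named here, the steps that bear on this change are the two swaps of the same aromatic substituent, from compound 1 to compound 2 and from compound 1 to compound 3, and neither moved the number beyond the scatter. The expectation is therefore that compound 4 will behave like the three measured compounds, with a step of a 1.2-fold lower number from compound 1 to compound 4 (0.08 log units; within the scatter) that stays within the scatter. For compound 4 the estimate in this assay is 18 nM, with a range from 7 nM to 45 nM.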

Compound 4, half-maximal effective concentration: 282 nM
Compound 4: middle estimate off by 16-fold (1.19 log units), on the low side; the measured number lies above the stated range.
By their numbers in this assay, from the lowest: compounds 2, 3 and 1 (each within the scatter of the next); then compound 4.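

The three earlier groups could not be told apart, which made this aromatic carbon look tolerant, but ethyl stands apart from each of them in this assay and the gap is wide: ethyl in place of cyano gives a 13-fold higher number from compound 1 to compound 4 (1.12 log units; beyond the scatter) while ethyl in place of bromo gives a 19-fold higher number from compound 3 to compound 4 (1.27 log units; beyond the scatter) and ethyl in place of 1,1,2,2,2-pentafluoroethyl gives a 24-fold higher number from compound 2 to compound 4 (1.38 log units; beyond the scatter) so all three steps are large. A simple count of size does not separate the groups, since cyano and ethyl both have 2 heavy atoms and no ring. The 1,1,2,2,2-pentafluoroethyl group of compound 2 has the same carbon chain as ethyl with fluorine on it, yet its number stays with those of compounds 1 and 3.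

A methoxy group, an amine, a carboxylic acid or a longer chain such as propyl on this carbon would show whether ethyl is a lone exception or one of many groups that raise the number. No measurement at hand bears on why ethyl behaves so differently from the other three groups.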